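The source may report more compounds than this note shows. Statements on the series, on what has been measured and on what is new or still open speak of the compounds shown alone.

Measured so far in a functional assay on OVCAR-8 cells (Homo sapiens) for inhibition, read by sulforhodamine B assay, with a stated time of 48 h, tested at 0.01 uM; a higher number here means a weaker effect of the compound at the concentration tested, a lower number a stronger effect:
Compound 1, `COc1cc(Cl)cc(-c2nn(-c3cccc(NC(=O)Nc4cccc(C(F)(F)F)c4)c3)cc2-c2ccncc2)c1`: 97%
Compound 2, `COc1cc(Cl)cc(-c2nn(-c3cccc(NC(=O)c4cccc(C(F)(F)F)c4)c3)cc2-c2ccncc2)c1`: 103%

Compound 1 holds the lower of the two numbers, with compound 2 nearest; the step of a number 6 percentage points higher from compound 1 to compound 2 (within the scatter) lies within the scatter, so on these numbers the two compounds are not separated. The next compound, compound 3 `COc1cc(Cl)cc(-c2nn(-c3cccc(NC(=O)Nc4cc(C(F)(F)F)cc(C(F)(F)F)c4)c3)cc2-c2ccncc2)c1`, departs from compound 1 by trifluoromethyl in place of hydrogen on an aromatic carbon. Going by the values given here, no measured step covers this change: the one step on record, a number 6 percentage points higher from compound 1 to compound 2 (within the scatter), exchanges the group on the carbonyl carbon and gives no information on a second trifluoromethyl group on the six-membered aromatic ring of carbon only. Among the compounds with values here, with compound 1 showing little effect in this assay and no step to suggest movement, the expected step is no change at the digits printed from compound 1 to compound 3 (within the scatter), nothing beyond the scatter. Compound 3 is therefore estimated at 97% in this assay, between 85% and 107%.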

Compound 3, a percentage reported as activity, at one concentration (the size of the read-out at that concentration, not a potency): 99%
Compound 3: middle estimate off by 2 percentage points, on the low side, within the range that was stated.
By their numbers in this assay, from the lowest: compounds 1, 3 and 2 (each within the scatter of the next).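

In this assay, trifluoromethyl in place of hydrogen on an aromatic carbon, meta to a large group and meta to a trifluoromethyl group, gives a number 2 percentage points higher from compound 1 to compound 3 (within the scatter). Going by these compounds alone, this is the first reading of a change on the six-membered aromatic ring of carbon only, as the earlier step concerned the group on the carbonyl carbon, and on these numbers the added group does not separate compound 3 from compound 1. No supporting measurement bears on this result.

A single added group at one position, read at one concentration, leaves open whether the flat result extends to other groups there, such as an amine or a carboxylic acid. It also leaves open whether compound 1 and compound 3 would separate at higher concentrations in this assay.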